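Legumain inhibitors: aryl substituent swap at the biaryl tail

The source may hold more compounds than are shown below. What is called first, only, known or untested is meant among the compounds shown, and "the series" means these compounds.

Measured compounds:
compound 1 `C[C@@H](C(=O)N[C@H](C#N)CC(N)=O)N(Cc1ccc(-c2cccc(C(F)(F)F)c2)cc1)S(C)(=O)=O` gives 601 nM in an assay on isolated protein for inhibition of legumain (Homo sapiens), with stated times of 2 min and 60 min; a higher number here means a weaker inhibitor, a lower number a stronger inhibitor
compound 2 `CC(C)Oc1cccc(-c2ccc(CN([C@H](C)C(=O)N[C@H](C#N)CC(N)=O)S(C)(=O)=O)cc2)c1` gives 5050 nM in this assay

Compound 2 holds the highest of the two numbers recorded so far. Its nearest neighbour in value, compound 1, sits markedly lower, and that gap is beyond the scatter.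

Compound 3 `C[C@H](C(=O)N[C@H](C#N)CC(N)=O)N(Cc1ccc(-c2cccc(C(F)(F)F)c2)cc1)S(C)(=O)=O` is not yet measured. Relative to compound 2 the change is trifluoromethyl in place of isopropoxy on an aromatic carbon. Within the data shown here, no measured pair in the set isolates this particular exchange, so its effect is not known from the data. Compound 1 does carry the same trifluoromethyl-bearing tail and returns a low number, but it is not a single-change partner of compound 3, so it serves only as a loose pointer.

The expectation for compound 3 is a move to a lower number, of moderate size, estimated as a 2.5-fold lower number from compound 2 to compound 3 (0.40 log units; beyond the scatter). Compound 3 is estimated at 2000 nM, within the range 600 nM to 6000 nM.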

Compound 3, half-maximal inhibitory concentration: > 10000 nM
Compound 3 gave a limit, no number; the forecaster's own chance of this, stated with the estimate: 5%; middle value at least 5.0-fold (0.69 log units) from the limit.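

In this assay compound 3 gives > 10000 nM, which is a limit of the assay and not a number. Configuration at the saturated chain carbon carries a large effect with the trifluoromethyl tail, since going from drawn S to drawn R gives an at least 16-fold higher number from compound 1 to compound 3 (1.22 log units; beyond the scatter), and this step isolates that single stereocentre: the fact that compounds 1 and 3 differ only in the configuration as drawn. The exchange on the aromatic carbon, trifluoromethyl in place of isopropoxy, reads only as an at least 1.9-fold higher number from compound 2 to compound 3 (0.29 log units; that floor lies within the scatter), so in this configuration the data do not establish a real change from that exchange.

As far as these compounds go, how far compound 3 lies past its limit remains open, so both steps stand as floors. Also open, from the compounds shown here alone, is how an amine or a carboxylic acid on that aromatic carbon would read in this assay with either configuration at the chain carbon.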